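The compounds below may be only part of what the source reports. "The series", "measured", "known", "first", "only" and "open" are said of these compounds alone.

Measured so far in a functional assay on VCaP cells (Homo sapiens) for antiproliferative activity, read by CCK-8 assay, with a stated time of 6 days; a higher number here means a weaker inhibitor, a lower number a stronger inhibitor:
compound 1, `CCN(c1ccc(C#N)c(Cl)c1)c1cc(-c2ccccc2)ccc1C`, gives > 30000 nM
compound 2, `CCN(c1cccc(-c2ccccc2)c1)c1ccc(C#N)c(Cl)c1`, gives "not determined" (no result reported)

Compound 1 stands at the edge of what this assay can report. Its value of > 30000 nM is a limit of the assay and not a number, and the record of compound 1 is summed up by the limit of > 30000 nM in this assay, at which 1 of the 2 values shown sits. Among the measured compounds shown here, for compound 2 no result was reported, so nothing can be read from the pair of compound 1 and compound 2, and no step between measured compounds is available.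

Compound 3, `CCN(c1ccc(C#N)c(Cl)c1)c1cc(-c2ccnn2C)ccc1C`, differs from compound 1 in one place: 1-methyl-1H-pyrazol-5-yl in place of phenyl on an aromatic carbon. With compound 1 sitting at a limit, there is no measured change to build on, and the single replacement of one aromatic ring by another of the same size gives no ground to expect a large shift. The expected step of a number no higher from compound 1 to compound 3 (the limit leaves the size open) is therefore none beyond the scatter, with the chance that compound 3 again returns only a limit judged high. Compound 3 is expected to give 30000 nM, within a range from 8000 nM to 60000 nM.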

Compound 3, half-maximal inhibitory concentration: 1670 nM
The estimate for compound 3 lay 18-fold (1.25 log units) above the measured number, and the stated range ends above it.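

In this assay the exchange of phenyl for 1-methyl-1H-pyrazol-5-yl on this aromatic carbon, meta to a large group and para to a methyl group, gives an at least 17-fold lower number from compound 1 to compound 3 (1.25 log units; beyond the scatter) and so provides the first measured number among the compounds shown. It also shows that the read-out responds to the ring at this position, even though the heavy-atom count stays the same and a six-membered carbon ring gives way to a five-membered ring with 2 hetero atoms. From the compounds shown here alone, compound 1 stands at a limit and not at a number, so the step has a lower bound and its full size stays open: the limit of > 30000 nM in this assay, at which 1 of the 3 values shown sits.

A single replacement cannot separate the contribution of the ring nitrogens from that of the methyl group on the new ring or of the smaller ring itself, and the compounds shown hold no measurement that would assign the gain to any one of these. Also open, going by these compounds, is how a pyridine ring, a pyrazole ring without the methyl group or an amine would fare at this carbon, and whether the methyl group on the shared core matters here.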